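A few compounds are considered here, and "the series" means these few. Any claim that something is new, unique, unknown or untested is made for them only; others in the source may bear on it.

Measured so far:

- compound 1 `CN1CCN(c2ccc(C3=NN(S(=O)(=O)c4ccc(C#N)cc4)C(c4ccc(N(C)C)cc4)C3)cc2)CC1` — 100%
- compound 2 `CN(C)c1ccc(C2CC(c3ccc(-n4ccnc4)cc3)=NN2C(=O)CCCl)cc1` — -2.5%
- compound 3 `CN(C)c1ccc(C2CC(c3ccc(-n4ccnc4)cc3)=NN2C(=O)c2ccc(F)cc2)cc1` — -3.5%

In a functional assay on NCI-H1975 cells (Homo sapiens) for inhibition, read by sulforhodamine B assay, tested at 10 uM (a higher number here means more inhibition at the concentration tested (going by the name of the read-out), a lower number less inhibition), compound 3 gives -3.5%, the smallest of the three numbers; compound 2 with -2.5% sits within the scatter of it, while compound 1 with 100% stands far above both. Compound 4 `CN(C)c1ccc(C2CC(c3ccc(-n4ccnc4)cc3)=NN2S(=O)(=O)c2ccc(C#N)cc2)cc1` is the next structure. It keeps the core of compound 3 and changes one group: (4-cyanophenyl)sulfonyl in place of (4-fluorophenyl)carbonyl on an amine nitrogen in a ring. Among the compounds with values here, the one measured step that touches the same position, a number 1 percentage points lower from compound 2 to compound 3 (within the scatter), swapped one carbonyl group for another and stayed flat. Within the data shown here, no measured step exchanges a carbonyl for a sulfonyl. Among the measured compounds shown here, compound 1, which carries the same (4-cyanophenyl)sulfonyl group but a different group on the other side of its core, gives 100%; that value is the only hint that this group could lift the number. The estimate for compound 4 is therefore a rise, a number 58.5 percentage points higher from compound 3 to compound 4 (beyond the scatter), with wide uncertainty because only compound 1 with 100% supports it. Compound 4 is expected to give 55%, somewhere between 0% and 100%.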

Compound 4, a percentage reported as inhibition, at one concentration (the size of the read-out at that concentration, not a potency): 0.7%
Estimate against measurement, compound 4: 54.3 percentage points above, within the range that was stated.
By their numbers in this assay, from the lowest: compounds 3, 2 and 4 (each within the scatter of the next); then compound 1.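

In this assay, with 1H-imidazol-1-yl on the aromatic carbon, (4-cyanophenyl)sulfonyl on the amine nitrogen in a ring reads the same as either carbonyl group: the number comes out a number 4.2 percentage points higher from compound 3 to compound 4 (within the scatter) and a number 3.2 percentage points higher from compound 2 to compound 4 (within the scatter) so this position has now stayed flat across a sulfonyl as well as two carbonyl groups. Within the data shown here, the high number of compound 1 therefore does not come with the (4-cyanophenyl)sulfonyl group alone, since with that group held fixed, 1H-imidazol-1-yl in place of 4-methylpiperazin-1-yl gives a number 99.3 percentage points lower from compound 1 to compound 4 (beyond the scatter) and this is the one large step in the set. No outside data here explain why this exchange has such a large effect.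

From the compounds shown here alone, it remains open whether 4-methylpiperazin-1-yl would keep the number high with (4-fluorophenyl)carbonyl on the ring nitrogen. Going by these compounds, it is also open how a morpholin-4-yl group or an unsubstituted piperazin-1-yl group would read on that aromatic carbon.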